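Notes on a fluoro step in the benzylamino series

The compounds below may be only part of what the source reports. "The series", "measured", "known", "first", "only" and "open" are said of these compounds alone.

Three compounds of the series have read-outs so far. Compound 1 `Cc1ccccc1Nc1nc(Nc2ccccc2)ncc1Cl` reads > 100000 nM in an ADME assay on L02 cells (Homo sapiens) for inhibition, read by CCK-8 assay, with a stated time of 48 h (on this read-out higher numbers stand for weaker inhibition of growth and lower numbers for stronger inhibition of growth), and this is a limit of the assay, not a number. In this assay compound 2 `Cc1ccccc1Nc1nc(Nc2ccc(N3CCNCC3)cn2)ncc1Cl` gives 1850 nM, and compound 3 `CN1CCN(c2ccc(Nc3ncc(Cl)c(NCc4ccccc4)n3)nc2)CC1` gives 20300 nM. Compound 3 therefore holds the higher of the two true numbers, and compound 2 lies lower by a gap beyond the scatter. Going by the values given here, no measured pair differs in only one place, so no single change has a measured size yet.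

The next compound is compound 4 `CN1CCN(c2ccc(Nc3ncc(Cl)c(NCc4ccc(F)cc4)n3)nc2)CC1`, which takes compound 3 from benzyl to 4-fluorobenzyl. The difference is fluoro in place of hydrogen on an aromatic carbon, para to a large group. Among the compounds with values here, with no measured step to lean on, the expectation in this assay rests on compound 3 at 20300 nM, and no step beyond the scatter is expected. The estimated change is a 1.3-fold lower number from compound 3 to compound 4 (0.10 log units; within the scatter). For compound 4 the expected value is 16000 nM, with an estimated range from 7000 nM to 40000 nM.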

Compound 4, concentration for 50% growth inhibition: 39700 nM
Beside the measured number, compound 4's estimate is 2.5-fold (0.39 log units) below it, within the range that was stated.
By their numbers in this assay, from the lowest: compound 2; then compounds 3 and 4 (each within the scatter of the next). At a limit, above all of these: compound 1.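

In this assay, going by these compounds alone, fluoro in place of hydrogen on an aromatic carbon, para to a large group, gives a 2.0-fold higher number from compound 3 to compound 4 (0.29 log units; within the scatter), and this is the first change with a measured size. At this position of the benzyl group, one added fluorine does not move the read-out beyond the scatter, so the benzyl and 4-fluorobenzyl groups cannot be told apart on these two compounds alone. Nothing in the data on hand bears on a cause for this step.

From the compounds shown here alone, whether a larger group at the same position, such as trifluoromethyl, methoxy or a carboxylic acid, would give a step beyond the scatter remains open, as does the size of the fluoro step at any other position of the benzyl group. Also open, going by these compounds, is how an amine or a longer chain in place of the benzyl group would compare in this assay with compound 3, which gives 20300 nM there.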